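Halogen swap on the urea aryl: compound 3 to compound 4

The source may report more compounds than this note shows. Statements on the series, on what has been measured and on what is new or still open speak of the compounds shown alone.

Measured compounds in a functional assay on HepG2 cells (Homo sapiens) for antiproliferative activity, read by MTT assay; on this read-out lower numbers stand for stronger inhibition and higher numbers for weaker inhibition:
Compound 1 `COc1ccc(NC(=O)Nc2cccc(CNc3ncnc4ccccc34)c2)cc1` reaches only the limit > 50000 nM, which is a limit and not a number.
Compound 2 `O=C(Nc1cccc(CNc2ncnc3ccccc23)c1)Nc1ccccc1F` gives 17500 nM.
Compound 3 `O=C(Nc1ccc(F)cc1)Nc1cccc(CNc2ncnc3ccccc23)c1` gives 41500 nM.

Compound 3 holds the highest of the two numbers, its nearest neighbour being compound 2 with a 2.4-fold higher number from compound 2 to compound 3 (0.38 log units; beyond the scatter); compound 1 sits at a limit (the limit of > 50000 nM in this assay, at which 1 of the 3 values shown sits). Compound 4 `O=C(Nc1cccc(Cl)c1)Nc1cccc(CNc2ncnc3ccccc23)c1` differs from compound 3 by 3-chlorophenyl in place of 4-fluorophenyl on an amide-type nitrogen. For the measured compounds named here, no measured step exchanges fluoro for chloro; the steps that bear on aryl substitution are an at least 2.8-fold lower number from compound 1 to compound 2 (0.45 log units; beyond the scatter), an at least 1.2-fold lower number from compound 1 to compound 3 (0.08 log units; that floor lies within the scatter) and a 2.4-fold higher number from compound 2 to compound 3 (0.38 log units; beyond the scatter), all small to modest. A step of similar size, direction uncertain, is therefore expected in this assay. Compound 4 is estimated at 30000 nM, between 10000 nM and 90000 nM, meaning an expected 1.4-fold lower number from compound 3 to compound 4 (0.14 log units; within the scatter).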

Compound 4, half-maximal inhibitory concentration: > 50000 nM
Compound 4: a limit, no number; the forecaster's own chance of this, stated with the estimate: 30%; middle value at least 1.6-fold (0.22 log units) from the limit.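

In this assay compound 4 gives > 50000 nM, a limit and not a number. For the compounds shown here, with 3-chlorophenyl on the amide-type nitrogen, the series shows an at least 2.8-fold higher number from compound 2 to compound 4 (0.45 log units; beyond the scatter), while the comparison with 4-fluorophenyl gives only an at least 1.2-fold higher number from compound 3 to compound 4 (0.08 log units; that floor lies within the scatter), so the 2-fluorophenyl group keeps the only measured number clearly separated from compound 4. The step linking compound 1 and compound 4 cannot be read, since both values are limits: the limit of > 50000 nM in this assay, at which 2 of the 4 values shown sit.

As far as these compounds go, what the halogen and its place each contribute stays open, as the step to compound 4 changes both at once. A 3-fluorophenyl or 4-chlorophenyl group would separate the two.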